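The source may hold more compounds than are shown below. What is called first, only, known or untested is meant among the compounds shown, and "the series" means these compounds.

For the measured compounds named here, in a functional assay on HL-60 cells (Homo sapiens) for cytotoxicity, read by WST assay, with a stated time of 48 h (on this read-out higher numbers stand for weaker inhibition and lower numbers for stronger inhibition), compound 1 `O[C@@H](c1ccccc1)[C@H]1CO[C@H](c2ccccc2)[C@@H](C/C=C/c2cccc(F)c2)C1` gives 9170 nM and compound 2 `O=[N+]([O-])c1ccccc1/C=C/C[C@H]1C[C@@H]([C@@H](O)c2ccccc2)CO[C@@H]1c1ccccc1` gives 7250 nM, so compound 2 stands level with compound 1, the only other measured compound. Compound 3 `O[C@@H](c1ccccc1)[C@H]1CO[C@H](c2ccccc2)[C@@H](C/C=C/c2ccncc2)C1` differs from compound 2 by pyridin-4-yl in place of 2-nitrophenyl on a double-bonded chain carbon bound to a double-bonded chain carbon, with pyridin-4-yl in place of 2-nitrophenyl on a double-bonded chain carbon bound to a double-bonded chain carbon. Going by the values given here, the one measured step at this place, a 1.3-fold lower number from compound 1 to compound 2 (0.10 log units; within the scatter), is small, and no measured compound carries pyridin-4-yl. No step beyond the scatter is therefore expected in this assay. The expected step is a 1.2-fold higher number from compound 2 to compound 3 (0.09 log units; within the scatter). Compound 3 is estimated at 9000 nM, with an expected range of 4000 nM to 22000 nM.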

Compound 3, half-maximal inhibitory concentration: > 100000 nM
Compound 3: no number, only a limit; the forecaster's own chance of this, stated with the estimate: 15%; middle value at least 11-fold (1.04 log units) from the limit.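

In this assay, the group on a double-bonded chain carbon bound to a double-bonded chain carbon now proves able to shift the read-out: 3-fluorophenyl and 2-nitrophenyl showed no step beyond the scatter, whereas pyridin-4-yl gives an at least 13-fold higher number from compound 2 to compound 3 (1.13 log units; beyond the scatter) and an at least 10-fold higher number from compound 1 to compound 3 (1.03 log units; beyond the scatter) on the shared core. On these data alone, the result for compound 3 is a limit, so the full size of both steps stays unknown: the limit of > 100000 nM in this assay, at which 1 of the 3 values shown sits.

As far as these compounds go, whether the ring nitrogen of pyridin-4-yl goes with this change remains open. A plain phenyl or an aminophenyl group at this place would bear on that question.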